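Cyclopropyl to Cyclohexyl Amide: Expected Vero Cell Cytotoxicity

The source may report more compounds than this note shows. Statements on the series, on what has been measured and on what is new or still open speak of the compounds shown alone.

Measured compounds:
- compound 1 `CC(C)(C)OC(=O)Nc1cccc(-c2csc(NC(=O)c3ccc([N+](=O)[O-])o3)n2)c1`: "not determined" (no result reported) in an ADME assay on Vero cells (Chlorocebus sabaeus) for cytotoxicity, read by MTT assay, with a stated time of 72 h; a lower number here means a stronger inhibitor, a higher number a weaker inhibitor
- compound 2 `O=C(Nc1nc(-c2cccc(NC(=O)C3CC3)c2)cs1)c1ccc([N+](=O)[O-])o1`: 35700 nM

In this assay compound 2 gives 35700 nM and holds the only number shown, since compound 1 has no reported result. Compound 3 `O=C(Nc1nc(-c2cccc(NC(=O)C3CCCCC3)c2)cs1)c1ccc([N+](=O)[O-])o1` differs from compound 2 by one change: cyclohexyl in place of cyclopropyl on a carbonyl carbon. Among the compounds with values here, no measured pair shows the effect of such a change, so the step from compound 2 to compound 3 in this assay is expected to be small, probably within the usual scatter, perhaps leaning toward a somewhat lower number; the expected step is a 1.4-fold lower number from compound 2 to compound 3 (0.15 log units; within the scatter). Compound 3 is estimated at 25000 nM, with a range from 8000 nM to 80000 nM.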

Compound 3, half-maximal inhibitory concentration: 21900 nM
Beside the measured number, compound 3's estimate is 1.1-fold (0.06 log units) above it, and the stated range covers the measured number.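

Within the data shown here, this is the first pair that tests this position in this assay, and replacing cyclopropyl with cyclohexyl on the carbonyl carbon gives a 1.6-fold lower number from compound 2 to compound 3 (0.21 log units; within the scatter). The two compounds therefore cannot be told apart in this readout, even though the new ring is clearly larger. Nothing available explains this result, so it stands as an observation only.

The compounds shown leave open whether a different kind of group on this carbonyl carbon, such as an amine or a longer straight carbon chain, would move the number beyond the usual scatter.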